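This account rests on a few compounds, and the source may have more. Where it says the series, first, only, none or still open, it means among the compounds named here.

Three compounds carry measured numbers in a physicochemical assay for lipophilicity, read by HPLC, at pH 3.0; on this read-out lower numbers stand for lower lipophilicity and higher numbers for higher lipophilicity. Compound 1 `NCc1csc(NC(=O)c2cc3ccccc3[nH]2)n1` gives 1.1, compound 2 `NCc1csc(NC(=O)c2ccn[nH]2)n1` gives 0, and compound 3 `Cc1csc(NC(=O)c2cc(C(C)(C)C)nn2Cc2ccccc2)n1` gives 4.7. Compound 3 stands highest of the three: its nearest neighbour is compound 1, which lies well beyond the scatter below it, and compound 2 lies further down still.

Compound 4 `CC(C)(C)c1cc(C(=O)Nc2cccc(CN)c2)n(Cc2ccccc2)n1` has not yet been measured in this assay. It differs from compound 3 in one place, with 3-(aminomethyl)phenyl in place of 4-methyl-1,3-thiazol-2-yl on an amide-type nitrogen. Among the compounds with values here, no measured pair of compounds shares exactly this change, so the step can only be judged from the compounds at hand. Compound 1 and compound 2, which also carry an aminomethyl group, both sit far down the scale, while compound 3, which has none, sits at the top. On that ground the step from compound 3 to compound 4 is expected to run downward and to be large, estimated at a number 2.50 log units lower from compound 3 to compound 4 (beyond the scatter). Compound 4 is accordingly expected to give about 2.2 in this assay, with a likely range from 1.4 to 3.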

Compound 4, distribution coefficient: 2.2
Compound 4: middle estimate and measured number agree at the digits printed; the measured number falls inside the stated range.
By their numbers in this assay, from the lowest: compound 2; then compound 1; then compound 4; then compound 3.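

Within the data shown here, this is the only step here between compounds that differ in one place: in this assay, putting 3-(aminomethyl)phenyl in place of 4-methyl-1,3-thiazol-2-yl on the amide-type nitrogen gives a number 2.50 log units lower from compound 3 to compound 4 (beyond the scatter). Since the rest of the molecule stays the same, this shows directly that the read-out responds strongly to the group at this position, which compounds differing in several places could not show. The change is a double one, however, as a five-membered aromatic ring with 2 hetero atoms gives way to a six-membered ring of carbon only that also carries an aminomethyl group, and nothing at hand explains the size of the step.

Among these compounds, the single step therefore cannot say how much of the shift belongs to the ring and how much to the aminomethyl group. A plain phenyl on the amide-type nitrogen would separate the two parts, and a hydroxymethyl group or a carboxylic acid in place of the aminomethyl group would show how much the read-out depends on that amine.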